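The compounds below may be only part of what the source reports. "The series", "measured", "known", "first", "only" and "open" are said of these compounds alone.

In an ADME assay on HL-60 cells (Homo sapiens) for cytotoxicity, read by resazurin assay, with a stated time of 72 h (on this read-out lower numbers stand for an effect already at smaller amounts and higher numbers for an effect only at larger amounts of compound), three related compounds have been measured, and none of them gave a number. Compound 1 `NCCCCCCC(=O)Nc1nc2ccc(C(=O)c3ccccc3)cc2[nH]1` sits at a limit, > 30000 nM. Compound 2 `O=C(CCC1CCNCC1)Nc1nc2ccc(C(=O)c3ccccc3)cc2[nH]1` likewise reaches only a limit, > 30000 nM. The step that the two limits leave unreadable from compound 1 to compound 2 therefore cannot be read. Compound 3 `Nc1nc2ccc(C(=O)c3ccccc3)cc2n1C[C@@H]1CCCN1` also stops at a limit, > 30000 nM.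

Compound 4 `CC(C)(C)Cn1c(N)nc2ccc(C(=O)c3ccccc3)cc21` differs from compound 3 in one place: tert-butyl in place of pyrrolidin-2-yl on a saturated chain carbon bound to an aromatic nitrogen. Among the measured compounds shown here, no measured step bears directly on this change. For the measured compounds named here, what the record does offer is the limit of > 30000 nM in this assay, at which 3 of the 3 values shown sit, so every compound so far, whatever its side chain, has been too weak in this assay to yield a value. On that basis no step beyond the scatter is expected, and compound 4 is estimated to stay at the same limit, with the expected step that the limit leaves unreadable from compound 3 to compound 4. The estimate for compound 4 in this assay is 40000 nM, between 8000 nM and 200000 nM.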

Compound 4, half-maximal effective concentration: > 30000 nM
Compound 4 ended at the assay's limit; the forecaster's own chance of this, stated with the estimate: 80%; the middle value lies beyond the limit too.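

In this assay, among the compounds shown here, compound 4 gives > 30000 nM which is a limit, and with compound 3 also at a limit, no step from compound 3 to compound 4 can be read. The compounds shown leave open whether any side chain on the shared core yields an actual value in this assay at all.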